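The source may hold more compounds than are shown below. What is called first, only, known or untested is meant among the compounds shown, and "the series" means these compounds.

Compound 3, `CC1=C(C(=O)Nc2ccc([N+](=O)[O-])cc2)C(c2ccc(Br)cc2)N=C(SCc2ccc(Cl)cc2)N1`, is the closer parent of the unmeasured compound 4, `CC1=C(C(=O)Nc2ccc([N+](=O)[O-])cc2)C(c2ccc(Br)cc2)N=C(SCc2ccc(F)cc2)N1`, and the two differ by fluoro in place of chloro on an aromatic carbon. The same change has already been made once: compound 1, `COc1ccc(C2N=C(SCc3ccc(Cl)cc3)NC(C)=C2C(=O)Nc2ccc(Br)cc2)cc1`, becomes compound 2, `COc1ccc(C2N=C(SCc3ccc(F)cc3)NC(C)=C2C(=O)Nc2ccc(Br)cc2)cc1`, through (fluoro in place of chloro on an aromatic carbon). In a functional assay on the whole organism (artery, strain albino) with Rattus norvegicus as the target, with a stated time of 240 min, at a dose of 10 mg/kg by the oral route (a higher number here means more inhibition at the dose given (going by the name of the read-out), a lower number less inhibition), compound 1 gives 29.2%, while compound 2 gives 22.1%, so the step reads a number 7.1 percentage points lower from compound 1 to compound 2 (within the scatter). In this assay compound 3 gives 29.7%; how its core differs from that of compound 1 is not broken down here. Since the place of the change is the same in both pairs, the step from compound 3 to compound 4 is expected to be a number 5.7 percentage points lower from compound 3 to compound 4 (within the scatter), resting on the step of a number 7.1 percentage points lower from compound 1 to compound 2 (within the scatter). Compound 4 is therefore estimated to give 24% in this assay, with a range from 12% to 36%.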

Compound 4, a percentage reported as inhibition, in the whole organism at one dose (the size of the read-out at that dose, not a potency): 27.2%
For compound 4 the middle estimate is 3.2 percentage points below the measured one; measured number inside the range.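

In this assay, fluoro in place of chloro gives a number 2.5 percentage points lower from compound 3 to compound 4 (within the scatter), so on this core, as on the core of compound 1, the two halogens cannot be told apart. The change carries from one core to the other with no difference that can be resolved: the same change on two cores in this assay, a number 7.1 percentage points lower (within the scatter) from compound 1 to compound 2 and a number 2.5 percentage points lower (within the scatter) from compound 3 to compound 4, 4.6 percentage points apart, within the scatter of two such steps. Within the data shown here, this shows only that both steps stay within the scatter for these two pairs at a single oral dose; it does not fix a size for the step or show that it would hold on any other core.

The compounds shown leave open how a group other than the two halogens would read at this place, such as an amine, a carboxylic acid or trifluoromethyl. Also open, as far as these compounds go, is whether a longer chain in place of the 4-fluorobenzyl group would change the inhibition.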